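The compounds below may be only part of what the source reports. "The series", "measured", "known", "first", "only" and "open" are said of these compounds alone.

Measured compounds:
compound 1 `Cc1ccc([N+](=O)[O-])cc1S(=O)(=O)N(C)/N=C/c1cnn2ccccc12` — > 10000 nM in an assay on isolated protein for inhibition of phosphatidylinositol 4,5-bisphosphate 3-kinase catalytic subunit beta isoform (Homo sapiens), read by 33P incorporation, with a stated time of 60 min; a higher number here means a weaker inhibitor, a lower number a stronger inhibitor
compound 2 `Cc1ccc([N+](=O)[O-])cc1S(=O)(=O)N(C)/N=C/c1cnn2c(C)cccc12` — > 1000 nM

In this assay compound 1 gives only a limit, > 10000 nM. Compound 2 likewise gives only a limit, > 1000 nM. For the measured compounds named here, the one measured step, a step that the two limits leave unreadable from compound 1 to compound 2, is therefore unreadable, since one value sits at the limit of > 1000 nM in this assay, at which 1 of the 2 values shown sits, and the other at the limit of > 10000 nM in this assay, at which 1 of the 2 values shown sits. Compound 3 `Cc1ccc([N+](=O)[O-])cc1S(=O)(=O)N(C)/N=C/c1cnn2ccc(Cl)cc12` differs from compound 1 by chloro in place of hydrogen on an aromatic carbon. Going by the values given here, no measured step bears on this change, and compound 1 itself is known only as a limit, so no step in this assay beyond the scatter is expected. Compound 3 is estimated at 20000 nM (range 3000 nM to 100000 nM), a step that the limit leaves unreadable from compound 1 to compound 3 that is expected to remain within the limit.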

Compound 3, half-maximal inhibitory concentration: 390 nM
Compound 3: the middle estimate sits 51-fold (1.71 log units) above what was measured; measured number outside the range, below it.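

A chloro group on the six-membered aromatic ring, opposite the ring nitrogen, gives an at least 25-fold lower number from compound 1 to compound 3 (1.40 log units; beyond the scatter) in this assay, the only step among these compounds whose size can be read. The step to compound 2 cannot be read. The true size of the chloro step also stays unknown, because compound 1 is known only as a limit: the limit of > 10000 nM in this assay, at which 1 of the 3 values shown sits.

Going by these compounds, whether bromo, fluoro or methoxy at this same position would also lower the number stays open. So does whether chloro would do so elsewhere on this ring.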